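This account rests on a few compounds, and the source may have more. Where it says the series, first, only, none or still open, it means among the compounds named here.

Measured so far:
Compound 1, `COC(=O)/C(C)=C/C#Cc1[nH]cnc2ncnc1-2`, in a functional assay on K562 cells (Homo sapiens) for inhibition, read by thymidine incorporation, with a stated time of 48 h, tested at 10 ug/mL (a lower number here means less inhibition, a higher number more inhibition at the concentration tested (going by the name of the read-out)), gives 100%.
Compound 2, `C/C(=C\C#Cc1[nH]cnc2ncnc1-2)CO`, in this assay gives 17%.
Compound 3, `COC(=O)/C(C)=C/C=C/c1[nH]cnc2ncnc1-2`, in this assay gives 20%.

Compound 4, `C/C(=C\C=C\c1[nH]cnc2ncnc1-2)CO`, is not yet measured. Compound 2 arises from compound 1 by the change (hydroxymethyl in place of methoxycarbonyl on a double-bonded chain carbon bound to a double-bonded chain carbon and a saturated chain carbon), and that step was a number 83 percentage points lower from compound 1 to compound 2 (beyond the scatter). Compound 4 arises from compound 3 by hydroxymethyl in place of methoxycarbonyl on a double-bonded chain carbon bound to a double-bonded chain carbon and a saturated chain carbon, the same change at the same kind of place; how the core of compound 3 differs from the core of compound 1 is not broken down here. The earlier step started from a high value and fell far. Compound 3 already sits low, close to compound 2, so for compound 4 only a small downward step is expected, a number 12 percentage points lower from compound 3 to compound 4 (beyond the scatter), because compound 3 gives 20% and leaves little room. Compound 4 is expected to give about 8%, between 0% and 20%.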

Compound 4, a percentage reported as inhibition, at one concentration (the size of the read-out at that concentration, not a potency): 6%
Compound 4: the middle estimate sits 2 percentage points above what was measured; measured number inside the range.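

On both cores in this assay, hydroxymethyl in place of methoxycarbonyl lowers the number, but the size of the drop does not carry over from one core to the other: the same change on two cores in this assay, a number 83 percentage points lower (beyond the scatter) from compound 1 to compound 2 and a number 14 percentage points lower (beyond the scatter) from compound 3 to compound 4, 69 percentage points apart, beyond the scatter of two such steps The new step is a number 14 percentage points lower from compound 3 to compound 4 (beyond the scatter), so the direction repeats. The starting point of this step is compound 3 at 20%. Two pairs show no general rule, however, and they do not explain why the drops differ in size.

From the compounds shown here alone, it remains open how other groups at this carbon, such as a carboxylic acid, an amide or an amine, would compare with methoxycarbonyl and hydroxymethyl. Going by these compounds, it is also open whether any of them would hold up equally on both cores.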